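A few compounds are considered here, and "the series" means these few. Any claim that something is new, unique, unknown or untested is made for them only; others in the source may bear on it.

Among the compounds with values here, compound 1 `CCCCCCCCCCCC(=O)OC[C@H](CSC[C@@H](N)C(=O)NCCCC(C)(C)CO)OC(=O)CCCCCCCCCCC` gives 30700 nM in an assay on HEK293 cells for agonist activity at Toll-like receptor 2 (Homo sapiens) (a higher number here means that more compound is needed for the effect, a lower number that less compound is needed), the highest of the three numbers measured so far; compound 2 `CCCCCCCCCCCC(=O)OC[C@H](CSC[C@@H](N)C(=O)NC(C)c1ccccc1)OC(=O)CCCCCCCCCCC` gives 9900 nM and compound 3 `CCCCCCCCCCCC(=O)OC[C@H](CSC[C@@H](N)C(=O)NCCCCCCCCCC(=O)O)OC(=O)CCCCCCCCCCC` gives 4400 nM. The two steps away from compound 1 both lower the number: a 3.1-fold lower number from compound 1 to compound 2 (0.49 log units; beyond the scatter) and a 7.0-fold lower number from compound 1 to compound 3 (0.84 log units; beyond the scatter), each beyond the scatter but modest. Compound 4 `CCCCCCCCCCCC(=O)OC[C@H](CSC[C@@H](N)C(=O)NCCN)OC(=O)CCCCCCCCCCC` differs from compound 1 by amino in place of 2-(hydroxymethyl)-2-methylpropyl on a saturated chain carbon, two bonds along the chain from an amide-type nitrogen. Neither measured step tests an amino at this place, so they bear on compound 4 only as showing that changes at the amide substituent of compound 1 have so far lowered the number modestly. A modest lowering is therefore expected, a 2.6-fold lower number from compound 1 to compound 4 (0.41 log units; beyond the scatter), with compound 4 estimated at 12000 nM, between 4000 nM and 40000 nM.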

Compound 4, half-maximal effective concentration: 5240 nM
For compound 4 the middle estimate is 2.3-fold (0.36 log units) above the measured one; low and high end bracket the measured number.
By their numbers in this assay, from the lowest: compounds 3, 4 and 2 (each within the scatter of the next, the first and the last beyond it); then compound 1.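

The amino in place of 2-(hydroxymethyl)-2-methylpropyl gives a 5.9-fold lower number from compound 1 to compound 4 (0.77 log units; beyond the scatter) in this assay, so a replacement of 1 heavy atom for 6 at this place still lowers the number. The other two steps, a 1.2-fold higher number from compound 3 to compound 4 (0.08 log units; within the scatter) and a 1.9-fold lower number from compound 2 to compound 4 (0.28 log units; within the scatter), place the short 2-aminoethyl within the scatter of both 9-carboxynonyl and 1-phenylethyl, although those two groups differ beyond it. No measurement offered here accounts for this result.

Going by these compounds, it remains open whether the step follows the amino itself or the loss of the larger group. A plain ethyl, or a longer chain ending in an amine, on the amide-type nitrogen would separate the two.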